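Removing one chloro from the core of compound 1

This account rests on a few compounds, and the source may have more. Where it says the series, first, only, none or still open, it means among the compounds named here.

Measured so far:
- compound 1, `ClCc1ccccc1Cn1cnc2c(Cl)nc(Cl)nc21`: 1730 nM
- compound 2, `Nc1nc(Cl)c2ncn(Cc3ccc(CCl)cc3)c2n1`: 10200 nM

In a functional assay on NCI-H226 cells (Homo sapiens) for cytotoxicity, read by sulforhodamine B assay, with a stated time of 48 h (a lower number here means a stronger inhibitor of growth, a higher number a weaker inhibitor of growth), compound 1 gives 1730 nM, the lowest of the two numbers, and compound 2 gives 10200 nM, a gap that lies beyond the usual scatter. Within the data shown here, compound 2 differs from compound 1 in more than one place, so no single step between measured compounds is available, and the two values show only that compound 1 inhibits growth more strongly.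

Compound 3, `ClCc1ccccc1Cn1cnc2c(Cl)ncnc21`, has not been measured. It differs from compound 1 by hydrogen in place of chloro on an aromatic carbon between two ring nitrogen atoms, meta to a chloro group and meta and para to a fused ring. Among the measured compounds shown here, with no measured step of this kind on this core, the size is uncertain; a modest loss in this assay is expected, possibly none beyond the scatter. Compound 3 is therefore estimated at 3000 nM (range 800 nM to 12000 nM), a step of a 1.7-fold higher number from compound 1 to compound 3 (0.24 log units; within the scatter) that is expected rather than known.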

Compound 3, concentration for 50% growth inhibition: 4570 nM
Compound 3: middle estimate off by 1.5-fold (0.18 log units), on the low side, and the stated range covers the measured number.
By their numbers in this assay, from the lowest: compound 1; then compound 3; then compound 2.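

Among these compounds, with this pair, the chloro on the aromatic carbon between two ring nitrogen atoms can be read on its own for the first time. In this assay, hydrogen in its place gives a modest loss of growth inhibition (a 2.6-fold higher number from compound 1 to compound 3 (0.42 log units; beyond the scatter)), so this chloro counts on the core of compound 1, though it is not needed for compound 3 to have a measurable value. Nothing available here accounts for the size of this step.

Going by these compounds, whether a fluoro, a methyl or a methoxy on that carbon would behave like chloro or like hydrogen remains open, and the amine that compound 2 carries there comes with other differences, so its contribution cannot be separated. Also open, on these data alone, is how the remaining chloro on the core contributes, and whether this step would keep its size with the chloromethyl group elsewhere on the benzyl ring.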